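Loss of One Methoxy Group: Two Matched Pairs Compared

This account rests on a few compounds, and the source may have more. Where it says the series, first, only, none or still open, it means among the compounds named here.

Compound 1, `COc1cc(-c2cc(/C=C/C(=O)c3ccc(N)cc3)[nH]n2)cc(OC)c1OC`, gives 69%.
Compound 2, `COc1ccc(-c2cc(/C=C/C(=O)c3ccc(N)cc3)[nH]n2)cc1OC`, gives 88%.
Compound 3, `COc1cc(C(=O)/C=C/c2cc(-c3cc(OC)c(OC)c(OC)c3)n[nH]2)cc(OC)c1OC`, gives 66%.

These three compounds were measured in a functional assay on SF-539 cells (Homo sapiens) for cytotoxicity, read by sulforhodamine B assay, with a stated time of 48 h, tested at 1 uM; on this read-out lower numbers stand for a stronger effect and higher numbers for a weaker effect at the one concentration tested. Compound 1 and compound 2 differ by one change, (hydrogen in place of methoxy on an aromatic carbon), and that step made a difference of a number 19 percentage points higher from compound 1 to compound 2 (beyond the scatter). Compound 3 reads close to compound 1, and its gap to compound 2 lies beyond the scatter; the difference between the cores of compound 1 and compound 3 is not broken down here.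

Compound 4, `COc1ccc(-c2cc(/C=C/C(=O)c3cc(OC)c(OC)c(OC)c3)[nH]n2)cc1OC`, has not yet been measured in this assay. It differs from compound 3 by hydrogen in place of methoxy on an aromatic carbon, which is the same change as that between compound 1 and compound 2, at the same kind of place. Among the measured compounds shown here, since compound 1 to compound 2 moved by a number 19 percentage points higher from compound 1 to compound 2 (beyond the scatter), the step from compound 3 to compound 4 is expected to be of similar size, a number 18 percentage points higher from compound 3 to compound 4 (beyond the scatter), though only one earlier example supports this. Compound 4 is therefore estimated at 84%, between 70% and 98%.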

Compound 4, a percentage reported as activity, at one concentration (the size of the read-out at that concentration, not a potency): 17%
For compound 4 the middle estimate is 67 percentage points above the measured one, and the stated range ends above it.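

In this assay, replacing one methoxy group with hydrogen on an aromatic carbon gave a number 49 percentage points lower from compound 3 to compound 4 (beyond the scatter), so the change did not carry over from one core to the other in either size or direction: the same change on two cores in this assay, a number 19 percentage points higher (beyond the scatter) from compound 1 to compound 2 and a number 49 percentage points lower (beyond the scatter) from compound 3 to compound 4, 68 percentage points apart, beyond the scatter of two such steps

For these two pairs, the step on the core of compound 1 therefore offers no usable guide to the step on the core of compound 3. The result does not show why the two cores part ways or which structural difference between them decides the outcome, and two pairs read at one concentration set no rule for any further core.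

The compounds shown carry only methoxy or hydrogen at this place, which leaves open how a hydroxy group, a fluorine atom or an ethoxy group would read there on either core. Also open, going by these compounds, is whether the strong effect of compound 4 at the one concentration tested would hold at other concentrations.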